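Pyrazolone amides: aryl swap on the ring nitrogen

This account rests on a few compounds, and the source may have more. Where it says the series, first, only, none or still open, it means among the compounds named here.

Measured so far:
Compound 1 `Cc1cc(=O)n(-c2cccc(F)c2)nc1C(=O)Nc1ccc(Oc2ncnc3[nH]ccc23)cc1` gives 9670 nM in a functional assay on MCF7 cells (Homo sapiens) for cytotoxicity, read by MTT assay, with a stated time of 72 h; a lower number here means a stronger inhibitor, a higher number a weaker inhibitor.
Compound 2 `Cc1cc(=O)n(-c2ccc(Br)cc2F)nc1C(=O)Nc1ccc(Oc2ncnc3[nH]ccc23)cc1` gives 3210 nM in this assay.
Compound 3 `Cc1cc(=O)n(-c2ccc(Br)cc2F)nc1C(=O)Nc1ccc(Oc2ncnc3c2ccn3C)c(F)c1` gives only a limit of the assay, > 60000 nM, in this assay.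

Compound 1 and compound 2 share one core and differ in a single place: 3-fluorophenyl in place of 4-bromo-2-fluorophenyl on an aromatic nitrogen. That change costs potency, a 3.0-fold higher number from compound 2 to compound 1 (0.48 log units; beyond the scatter).

Compound 3 carries a different core; how the two cores differ is not broken down here. Its value is a limit, (the limit of > 60000 nM in this assay, at which 1 of the 3 values shown sits), so no number is known for it.

Compound 4 `Cc1cc(=O)n(-c2cccc(F)c2)nc1C(=O)Nc1ccc(Oc2ncnc3c2ccn3C)c(F)c1` stands to compound 3 as compound 1 stands to compound 2: 3-fluorophenyl in place of 4-bromo-2-fluorophenyl on an aromatic nitrogen. The place is described in the same words in both pairs, so this is the same change, made twice among the compounds shown.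

With compound 3 already at the limit of this assay, and the earlier step of a 3.0-fold higher number from compound 2 to compound 1 (0.48 log units; beyond the scatter) pointing toward a weaker inhibitor, compound 4 is expected to be weaker still, an estimated step that the limit leaves unreadable from compound 3 to compound 4. Compound 4 is therefore expected to give about 150000 nM, within 60000 nM to 400000 nM, most likely reported only as a limit.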

Compound 4, half-maximal inhibitory concentration: > 60000 nM
Compound 4 ended at the assay's limit; the forecaster's own chance of this, stated with the estimate: 85%; the middle value is on the limit's open side.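

No step can be read from compound 3 to compound 4, because both values are limits in this assay and not numbers: the limit of > 60000 nM in this assay, at which 2 of the 4 values shown sit.

The compounds shown leave open whether 3-fluorophenyl in place of 4-bromo-2-fluorophenyl changes potency on the core of compound 3 as it does on the core of compound 1.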